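Swapping a Butylphenyl Arm for a Methoxyphenylethyl Chain

The compounds below may be only part of what the source reports. "The series", "measured", "known", "first", "only" and "open" are said of these compounds alone.

Compound 1 `CCCCCCCCS(=O)(=O)Nc1cc(-c2ccc(CCCC)cc2)ccc1C(=O)O` gives the lowest number of the three measured compounds in an assay on mitochondria (strain BALB/c) for inhibition of glycerol-3-phosphate acyltransferase 1, mitochondrial (Mus musculus), read by scintillation counting, with a stated time of 10 min; on this read-out lower numbers stand for stronger inhibition and higher numbers for weaker inhibition: compound 1 gives 15700 nM, while compound 2 `CCCCCCCCS(=O)(=O)Nc1ccc(-c2ccccc2F)cc1C(=O)O` gives 34600 nM and compound 3 `CCCCCCCCS(=O)(=O)Nc1ccc(C(=O)c2ccccc2OC)cc1C(=O)O` gives 59200 nM. Among the compounds with values here, the one measured single-point step, a 1.7-fold higher number from compound 2 to compound 3 (0.23 log units; within the scatter), lies within the scatter. Compound 4 `CCCCCCCCS(=O)(=O)Nc1cc(CCc2ccc(OC)cc2)ccc1C(=O)O` differs from compound 1 in one place: 2-(4-methoxyphenyl)ethyl in place of 4-butylphenyl on an aromatic carbon. Within the data shown here, no measured step bears directly on this change; the step from compound 2 to compound 3, which likewise exchanges one aromatic group for another, stayed within the scatter, so only a small step is expected here, if any, with a slight lean toward a higher number. Compound 4 is therefore estimated at 25000 nM, between 8000 nM and 80000 nM. The expected step is a 1.6-fold higher number from compound 1 to compound 4 (0.20 log units; within the scatter) in this assay.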

Compound 4, half-maximal inhibitory concentration: 43000 nM
The estimate for compound 4 lay 1.7-fold (0.24 log units) below the measured number, within the range that was stated.
By their numbers in this assay, from the lowest: compound 1; then compounds 2, 4 and 3 (each within the scatter of the next).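

At this position, para to a carboxy group, the change gives a 2.7-fold higher number from compound 1 to compound 4 (0.44 log units; beyond the scatter) in this assay. Unlike the one earlier step, this step lies beyond the scatter, so the group here can move the number, though only modestly, even with the count of heavy atoms unchanged. Nothing measured on these compounds explains the shift.

Going by these compounds, the change alters the link to the ring and the group on it together, so the share of each remains open. A 2-(4-butylphenyl)ethyl group or a 4-methoxyphenyl group at this position would separate them.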